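Cytotoxicity notes: from compound 3 to compound 4

This account rests on a few compounds, and the source may have more. Where it says the series, first, only, none or still open, it means among the compounds named here.

Measured so far:
Compound 1, `CS(=O)(=O)CCn1c(Cn2cc(S(C)(=O)=O)c3ccccc32)nc2ccccc21`, in an ADME assay on HEp-2 cells (Homo sapiens) for cytotoxicity, with a stated time of 4 days (a lower number here means that less compound is tolerated, a higher number that more compound is tolerated), gives > 100000 nM, which is a limit of the assay and not a number.
Compound 2, `CC(C)S(=O)(=O)c1cn(Cc2nc3cc(Cl)ccc3n2CCCS(C)(=O)=O)c2ccccc12`, in this assay gives > 100000 nM, again a limit of the assay.
Compound 3, `CS(=O)(=O)c1nn(Cc2nc3cc(Cl)ccc3n2CCCO)c2cnccc12`, in this assay gives > 100000 nM, also a limit of the assay.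

Compound 3 thus stands on a limit only, not on a number, and every value shown so far sits at the same place, as stated by the limit of > 100000 nM in this assay, at which 3 of the 3 values shown sit. Among the measured compounds shown here, no two measured compounds differ in one place, so no measured step is available to set a size against.

The change to the not yet measured compound 4, `CS(=O)(=O)c1nn(Cc2nc3cc(Cl)ccc3n2CCOCCO)c2cnccc12`, is 2-hydroxyethoxy in place of hydroxymethyl on a saturated chain carbon, two bonds along the chain from an aromatic nitrogen. The shared core, the chloro substituent and the methylsulfonyl group are unchanged; only the chain on the aromatic nitrogen is lengthened from hydroxymethyl to 2-hydroxyethoxy at that chain carbon.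

Given that compound 3 reaches the limit of this assay, the expectation for the step is none beyond the scatter, that is a step that the limit leaves unreadable from compound 3 to compound 4. Compound 4 is estimated in this assay at 150000 nM, with a range from 60000 nM to 400000 nM, and most likely reported again as a limit.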

Compound 4, half-maximal cytotoxic concentration: > 100000 nM
Compound 4 ended at the assay's limit; the forecaster's own chance of this, stated with the estimate: 85%; the middle value is on the limit's open side.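

Neither compound 3 nor compound 4 gives a number in this assay: each value is a limit of the assay, and no step can be read between these two compounds. The compounds shown leave open at what concentration any of them becomes cytotoxic, and whether 2-hydroxyethoxy in place of hydroxymethyl alters that concentration: the limit of > 100000 nM in this assay, at which 4 of the 4 values shown sit.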